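Chloro for a Basic Side Chain: an Untested Step

The source may report more compounds than this note shows. Statements on the series, on what has been measured and on what is new or still open speak of the compounds shown alone.

Measured so far:
Compound 1, `CCCCOc1ccc2c(Cl)ccnc2c1`: in a functional assay on RKO cells (Homo sapiens) for cytotoxicity, read by MTT assay, with a stated time of 48 h (a higher number here means a weaker inhibitor, a lower number a stronger inhibitor), compound 1 gives 3050 nM.
Compound 2, `C=CCOc1ccc2c(NCCCN(C)C)ccnc2c1`: in this assay compound 2 gives 3560 nM.

Compound 2 has the higher of these two numbers, yet compound 1 is its nearest neighbour and the gap between them falls within the scatter of repeated measurements, so no order between the two can be claimed. Compound 3, `C=CCOc1ccc2c(Cl)ccnc2c1`, has not been measured. It differs from compound 2 in one place: chloro in place of (3-(dimethylamino)propyl)amino on an aromatic carbon. Among the compounds with values here, no two measured compounds differ in exactly this way, so the size of this step cannot be read off from a neighbouring pair. Compound 3 does carry the chloro group found in compound 1, and the two measured numbers sit close together. The expectation for compound 3 is therefore a number near both, with no step beyond the scatter in either direction. Compound 3 is estimated at 3000 nM, with a range from 1000 nM to 9000 nM. This estimate means an expected step of a 1.2-fold lower number from compound 2 to compound 3 (0.07 log units; within the scatter), within the scatter.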

Compound 3, half-maximal inhibitory concentration: 2460 nM
Compound 3: the middle estimate sits 1.2-fold (0.09 log units) above what was measured; the range from low to high includes it.
By their numbers in this assay, from the lowest: compounds 3, 1 and 2 (each within the scatter of the next).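

Within the data shown here, at the aromatic carbon opposite the ring nitrogen, chloro in place of (3-(dimethylamino)propyl)amino can now be read directly: in this assay it gives a 1.4-fold lower number from compound 2 to compound 3 (0.16 log units; within the scatter), so exchanging this whole side chain for a single chloro leaves no step that can be told from the scatter. Among these compounds, the result also gives a first reading at the other end of the molecule, where vinyl in place of propyl on the saturated chain carbon bound to the oxygen gives a 1.2-fold lower number from compound 1 to compound 3 (0.09 log units; within the scatter), again no step beyond the scatter. Nothing available explains why either change leaves the number in this assay so little moved.

From the compounds shown here alone, whether a primary amine or a hydroxyl on that aromatic carbon would give a step beyond the scatter remains open. So does the effect of a longer chain on the oxygen, or of a longer chain between the two nitrogens of the side chain.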